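The source may report more compounds than this note shows. Statements on the series, on what has been measured and on what is new or still open speak of the compounds shown alone.

Measured in a functional assay on A549 cells (Homo sapiens) for antiproliferative activity, read by MTT assay, with a stated time of 48 h; on this read-out higher numbers stand for weaker inhibition of growth and lower numbers for stronger inhibition of growth:
- compound 1 `Cc1ccc(-c2cnc(N(Cc3ccccc3)Cc3ccc(C(=O)NO)cc3)s2)cc1`: 4410 nM
- compound 2 `CCN(Cc1ccc(C(=O)NO)cc1)c1ncc(-c2ccc(C)cc2)s1`: 2700 nM
- compound 3 `CCCCN(Cc1ccc(C(=O)NO)cc1)c1ncc(-c2ccc(C)cc2)s1`: 4780 nM

Compound 3 gives 4780 nM in this assay, but it cannot be ranked against compound 1 or compound 2, since its gaps to both lie within the scatter. The unmeasured compound 4 `Cc1ccc(-c2cnc(N(Cc3ccc(C(=O)NO)cc3)C(C)C)s2)cc1` differs from compound 3 in one place: isopropyl in place of butyl on a nitrogen on an aromatic ring.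

The most relevant evidence comes from the three measured swaps of the group on that same nitrogen. They gave a 1.6-fold lower number from compound 1 to compound 2 (0.21 log units; within the scatter), a 1.1-fold higher number from compound 1 to compound 3 (0.03 log units; within the scatter) and a 1.8-fold higher number from compound 2 to compound 3 (0.25 log units; within the scatter). For the measured compounds named here, none of these steps goes beyond the scatter, so no direction can be drawn from them, and no isopropyl compound has yet been measured. A similarly small move is therefore expected, with an estimated 1.3-fold lower number from compound 3 to compound 4 (0.10 log units; within the scatter) and no real change in either direction. For compound 4 the estimated value is 3800 nM, with an expected range from 1900 nM to 7500 nM.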

Compound 4, concentration for 50% growth inhibition: 3830 nM
For compound 4 the middle estimate is 1.0-fold (0.00 log units) below the measured one; low and high end bracket the measured number.
By their numbers in this assay, from the lowest: compounds 2, 4, 1 and 3 (each within the scatter of the next).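

In this assay, isopropyl in place of butyl gives a 1.2-fold lower number from compound 3 to compound 4 (0.10 log units; within the scatter), a methyl added to the chain carbon bound to the nitrogen gives a 1.4-fold higher number from compound 2 to compound 4 (0.15 log units; within the scatter), and isopropyl in place of benzyl gives a 1.2-fold lower number from compound 1 to compound 4 (0.06 log units; within the scatter). All three steps lie within the scatter, so branching at that chain carbon adds no readable change, and the ethyl, butyl, benzyl and isopropyl compounds cannot be told apart at this position on a nitrogen on an aromatic ring. No further measurement on these compounds helps to explain this result.

The compounds shown leave open whether a group of a different kind on this nitrogen, such as a chain ending in an amine or a carboxylic acid, would shift the number beyond the scatter. They also leave open whether a plain hydrogen there would do so.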